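The source may report more compounds than this note shows. Statements on the series, on what has been measured and on what is new or still open speak of the compounds shown alone.

Compound 1 `C#CCNC(=O)c1ccc(C(CC)(CC)c2ccc(OCC(O)C(C)(C)C)c(C)c2)n1CC`: 240 nM in an assay on HL-60 cells for agonist activity at vitamin D3 receptor (Homo sapiens), read by microscopy, with a stated time of 96 h; a lower number here means that less compound is needed, a higher number that more compound is needed for the effect
Compound 2 `CCn1c(C(=O)N(C)c2ccccc2)ccc1C(CC)(CC)c1ccc(OCC(O)C(C)(C)C)c(C)c1`: 6400 nM in this assay
Compound 3 `CCOc1ccc(NC(=O)c2ccc(C(CC)(CC)c3ccc(OCC(O)C(C)(C)C)c(C)c3)n2CC)cc1`: 630 nM in this assay

Among these three, compound 3 stands second highest: the steps of a 2.6-fold higher number from compound 1 to compound 3 (0.42 log units; beyond the scatter) and a 10-fold lower number from compound 2 to compound 3 (1.01 log units; beyond the scatter) place it between the other two, beyond the scatter on either side.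

Compound 4 `CCn1c(C(=O)OCc2ccccn2)ccc1C(CC)(CC)c1ccc(OCC(O)C(C)(C)C)c(C)c1` differs from compound 3 in one place: (pyridin-2-yl)methoxy in place of (4-ethoxyphenyl)amino on a carbonyl carbon. Going by the values given here, two measured steps bear on an exchange at this carbonyl carbon. In the step of a 27-fold higher number from compound 1 to compound 2 (1.43 log units; beyond the scatter) the hydrogen-bond donor on that carbon was lost; in the step of a 10-fold lower number from compound 2 to compound 3 (1.01 log units; beyond the scatter) one was brought back. Both steps point the same way: the variant without a donor on this carbonyl carbon gave a much higher number in this assay. Among the compounds with values here, compound 4 again carries no donor there, though as an ester rather than a tertiary amide, and no measured pair shows that exact exchange. The expectation is therefore an upward step of roughly the size seen before, a 4.8-fold higher number from compound 3 to compound 4 (0.68 log units; beyond the scatter), with wide uncertainty. For compound 4 the estimated value is 3000 nM, within a range from 800 nM to 12000 nM.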

Compound 4, half-maximal effective concentration: > 50000 nM
Compound 4 gave a limit, no number; the forecaster's own chance of this, stated with the estimate: 10%; middle value at least 16-fold (1.22 log units) away from the limit.
By their numbers in this assay, from the lowest: compound 1; then compound 3; then compound 2. At a limit, above all of these: compound 4.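

For compound 4, this assay gives a limit and not a number: the limit of > 50000 nM in this assay, at which 1 of the 4 values shown sits. At this carbonyl carbon, the ester carrying (pyridin-2-yl)methoxy lies far from both amides that keep the amide hydrogen, with an at least 79-fold higher number from compound 3 to compound 4 (1.89 log units; beyond the scatter) and an at least 200-fold higher number from compound 1 to compound 4 (2.31 log units; beyond the scatter). The tertiary amide also has no hydrogen-bond donor on this carbon, yet the ester still differs from it, with an at least 7.8-fold higher number from compound 2 to compound 4 (0.89 log units; beyond the scatter), so among these compounds the absence of a donor does not by itself fix the number.

As far as these compounds go, whether the step follows from the ester oxygen or from the pyridin-2-yl group stays open, and a (pyridin-2-yl)methylamino amide or a benzyl ester would separate the two. The compounds shown also leave open how a free carboxylic acid on this carbonyl carbon would read.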